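Ester in Place of Ether on a Benzyloxy Core

The source may report more compounds than this note shows. Statements on the series, on what has been measured and on what is new or still open speak of the compounds shown alone.

Among the measured compounds shown here, compound 2 `CCOCc1c(C)nc2c(OCc3ccccc3)cccn12` is one of two compounds so far examined in a functional assay on the whole organism with Rattus norvegicus as the target, with a stated time of 4 h, at a dose of 40 mg/kg by the intraperitoneal route (a higher number here means more inhibition at the dose given (going by the name of the read-out), a lower number less inhibition), and it stands highest of the two: compound 2 gives 84%. Compound 1 `CC(=O)c1c(C)nc2c(OCc3ccccc3)cccn12` shares the same core and differs only in a single group; in this assay compound 1 gives 57%. For the measured compounds named here, the one step measured so far, a number 27 percentage points higher from compound 1 to compound 2 (beyond the scatter), concerns ethoxymethyl in place of acetyl on an aromatic carbon.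

Compound 3 `Cc1nc2c(OCc3ccccc3)cccn2c1COC(=O)c1cccnc1` keeps the core and the benzyloxy group of compound 2 and alters the ethoxymethyl arm: (pyridin-3-yl)carbonyl in place of ethyl on an oxygen on a saturated carbon. Cut one bond further out, the change reads ethoxy to ((pyridin-3-yl)carbonyl)oxy.

Going by the values given here, no measured step touches this kind of change. Among the compounds with values here, the only step available, from acetyl to ethoxymethyl, concerns a different position and a different pair of groups, so it gives no direct guide to the size or direction of the step in this assay. Compound 3 is therefore expected to land near compound 2, with a step estimated at a number 14 percentage points lower from compound 2 to compound 3 (beyond the scatter), and a wide range. Compound 3 is expected to give about 70%, estimated between 35% and 95%.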

Compound 3, a percentage reported as inhibition, in the whole organism at one dose (the size of the read-out at that dose, not a potency): 87%
For compound 3 the middle estimate is 17 percentage points below the measured one, and the stated range covers the measured number.
By their numbers in this assay, from the lowest: compound 1; then compounds 2 and 3 (each within the scatter of the next).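

Swapping ethyl for (pyridin-3-yl)carbonyl on this oxygen gives a number 3 percentage points higher from compound 2 to compound 3 (within the scatter) in this assay, so compounds 2 and 3 cannot be told apart here even though the groups differ greatly. The earlier step changed what sits on an aromatic carbon, whereas this one shows that the far end of the arm can take a much larger group, with a six-membered aromatic ring and a carbonyl, and the read-out at this single dose stays level. Nothing measured here accounts for that result, which therefore stands as an observation with no explanation attached.

The compounds shown leave open which part of the new group matters, since a plain benzoyl group, with no ring nitrogen, or a simple acetyl on the same oxygen would separate the effect of the ring nitrogen from that of the carbonyl. An amine or a carboxylic acid at the end of the arm is also untested among these compounds, and a read-out at one dose cannot show whether compounds 2 and 3 would stay level at other doses.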